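Fluoro added to the anilide ring of compound 2

A few compounds are considered here, and "the series" means these few. Any claim that something is new, unique, unknown or untested is made for them only; others in the source may bear on it.

Compound 2 `O=C(Nc1ccc(Oc2ccnc3[nH]ccc23)cc1)c1nn(-c2ccc(Br)cc2)ccc1=O` gives 6240 nM in a functional assay on A549 cells (Homo sapiens) for cytotoxicity, read by MTT assay, with a stated time of 72 h (on this read-out higher numbers stand for weaker inhibition and lower numbers for stronger inhibition), the lowest of the three numbers in hand. Compound 1 `COc1ccc(-n2ccc(=O)c(C(=O)Nc3ccc(Oc4ccnc5[nH]ccc45)cc3)n2)cc1` gives 53100 nM and compound 3 `O=C(Nc1ccc(Oc2ccnc3[nH]ccc23)cc1)c1nn(-c2ccc(Br)cc2F)ccc1=O` gives 26100 nM; the steps of an 8.5-fold lower number from compound 1 to compound 2 (0.93 log units; beyond the scatter) and a 4.2-fold higher number from compound 2 to compound 3 (0.62 log units; beyond the scatter) both lie beyond the scatter. Compound 4 `O=C(Nc1ccc(Oc2ccnc3[nH]ccc23)c(F)c1)c1nn(-c2ccc(Br)cc2)ccc1=O` differs from compound 2 by fluoro in place of hydrogen on an aromatic carbon, placed ortho to a large group and meta to a large group. The measured step that bears most on this is a 4.2-fold higher number from compound 2 to compound 3 (0.62 log units; beyond the scatter), where fluoro entered the other aromatic ring; the step of a 2.0-fold lower number from compound 1 to compound 3 (0.31 log units; beyond the scatter) is less direct. A modest rise of similar size is therefore expected in this assay, with added uncertainty since the ring is different. Compound 4 is estimated at 14000 nM, range 4500 nM to 45000 nM, which means a step of a 2.2-fold higher number from compound 2 to compound 4 (0.35 log units; beyond the scatter).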

Compound 4, half-maximal inhibitory concentration: > 60000 nM
Compound 4: a limit, no number; the forecaster's own chance of this, stated with the estimate: 5%; middle value at least 4.2-fold (0.63 log units) away from the limit.
By their numbers in this assay, from the lowest: compound 2; then compound 3; then compound 1. At a limit, above all of these: compound 4.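

In this assay, fluoro in place of hydrogen on this ring, ortho to a large group and meta to a large group, gives an at least 9.6-fold higher number from compound 2 to compound 4 (0.98 log units; beyond the scatter). Earlier, fluoro had been seen only on the other aromatic ring, so this ring is now also shown to respond to that single change. Compound 4 stands at a limit of the assay, not at a number: the limit of > 60000 nM in this assay, at which 1 of the 4 values shown sits.

Open, going by these compounds, is how far the number for compound 4 really lies from that limit. Also open, on these data alone, is whether methyl, chloro or an amine at this carbon would bring a similar rise.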